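Propargyl removal on the oxygen: working notes

The source may hold more compounds than are shown below. What is called first, only, known or untested is meant among the compounds shown, and "the series" means these compounds.

compound 1 `C#CCO/N=C/c1c(-c2ccc(C)cc2)nc2c(C)cccn12`: 20 mg/kg
compound 2 `C#CCO/N=C/c1c(-c2ccc(C)cc2)nc2ccc(Br)cn12`: 20 mg/kg

In a functional assay on the whole organism (strain NMRI) with Mus musculus as the target, with a stated time of 0.5 h (on this read-out higher numbers stand for an effect only at larger amounts of compound and lower numbers for an effect already at smaller amounts), compound 1 stands level with compound 2 at the digits given; the two values lie within the usual scatter, so no order can be read between them. Compound 3 `Cc1ccc(-c2nc3c(C)cccn3c2/C=N/O)cc1` differs from compound 1 in one place: hydrogen in place of propargyl on an oxygen, that is, propargyloxy to hydroxy. Among the compounds with values here, no step between measured compounds is known, so the size of this change cannot be read from the series. A small loss is expected, within or just beyond the scatter: the step of a 1.5-fold higher number from compound 1 to compound 3 (0.18 log units; within the scatter) is estimated as modest. Compound 3 is expected at 30 mg/kg, with a range from 10 mg/kg to 100 mg/kg.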

Compound 3, minimum effective dose: 20 mg/kg
Compound 3: middle estimate off by 1.5-fold (0.18 log units), on the high side; measured number inside the range.
By their numbers in this assay, from the lowest: compounds 1, 2 and 3 (each within the scatter of the next).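

In this assay, hydrogen in place of propargyl on an oxygen gives no change at the digits printed from compound 1 to compound 3 (within the scatter), so this position now has a read step, which compounds 1 and 2 alone could not give. In this pair, the propargyl with its triple bond is not required to keep the read-out where it stands. Nothing at hand bears on why the two read alike.

From the compounds shown here alone, it remains open whether a methyl, a longer chain or a chain ending in an amine or carboxylic acid on this oxygen would shift the number. Going by these compounds, whether the same change reads alike on the core of compound 2 also remains open.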